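The source may report more compounds than this note shows. Statements on the series, on what has been measured and on what is new or still open speak of the compounds shown alone.

Measured so far in an ADME assay on Vero cells (Chlorocebus sabaeus) for cytotoxicity, read by MTT assay, with a stated time of 72 h; on this read-out lower numbers stand for higher toxicity in this test and higher numbers for lower toxicity in this test:

Compound 1 `O=c1nc(N2CCN(NCC3CCCCC3)CC2)sc2c([N+](=O)[O-])cc(C(F)(F)F)cc12`: 29.3 ug/mL
Compound 2 `O=c1nc(N2CCN(NCc3ccc(Br)cc3)CC2)sc2c([N+](=O)[O-])cc(C(F)(F)F)cc12`: > 64 ug/mL, a limit of this assay rather than a number

Compound 1 holds the only number shown; the other value is a limit. Compound 3 `Cc1ccc(CNN2CCN(c3nc(=O)c4cc(C(F)(F)F)cc([N+](=O)[O-])c4s3)CC2)cc1` differs from compound 1 by 4-methylphenyl in place of cyclohexyl on a saturated chain carbon bound to an amine nitrogen. Going by the values given here, only one measured step bears on this: an at least 2.1-fold higher number from compound 1 to compound 2 (0.33 log units; beyond the scatter), where the same cyclohexyl gave way to another aromatic ring. A shift of about that size toward the limit is therefore expected, a 1.9-fold higher number from compound 1 to compound 3 (0.27 log units; within the scatter). Compound 3 is estimated to give 55 ug/mL, somewhere between 25 ug/mL and 120 ug/mL, quite possibly reported only as a limit.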

Compound 3, half-maximal cytotoxic concentration: > 64 ug/mL
Compound 3 gave a limit, no number; the forecaster's own chance of this, stated with the estimate: 40%; middle value at least 1.1-fold (0.06 log units) away from the limit.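

In this assay, the change from cyclohexyl to an aromatic ring now has a second example: an at least 2.1-fold higher number from compound 1 to compound 3 (0.33 log units; beyond the scatter). The shift therefore appears with a methyl on the ring as well as with a bromo. Compound 2 and compound 3 both end at a limit, so the step between them cannot be read: the limit of > 64 ug/mL in this assay, at which 2 of the 3 values shown sit.

As far as these compounds go, how far either compound really lies past that limit remains open, so methyl and bromo cannot be ranked. Also open, from the compounds shown here alone, is whether a phenyl ring carrying an amine or a carboxylic acid would shift the number the same way.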